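Chain shortening across a matched pair in this series

The source may hold more compounds than are shown below. What is called first, only, known or untested is meant among the compounds shown, and "the series" means these compounds.

Compound 1 `C=C(C)CCC[C@]1(C)C2=CCC[C@](C)(C[C@@H](OC(C)=O)C3=CC(=O)OC3O)[C@H]2CC[C@H]1C` and compound 2 `C=C(C)CCC[C@]1(C)C2=CCC[C@](C)(C[C@H](O)C3=CC(=O)OC3O)[C@H]2CC[C@H]1C` differ in more than one place, and the difference between the two cores is not broken down here. In a functional assay on HeLa cells (Homo sapiens) for antiproliferative activity, read by XTT assay, with a stated time of 72 h (a higher number here means a weaker inhibitor, a lower number a stronger inhibitor), compound 1 gives 3500 nM, and compound 2 gives 3800 nM, two values within the scatter of each other. Compound 3 `C=C(C)CC[C@]1(C)C2=CCC[C@](C)(C[C@@H](OC(C)=O)C3=CC(=O)OC3O)[C@H]2CC[C@H]1C` carries 1-methylethenyl in place of 2-methylprop-2-en-1-yl on a saturated chain carbon, two bonds along the chain from a saturated ring carbon relative to compound 1; in this assay compound 3 gives 6700 nM, a step of a 1.9-fold higher number from compound 1 to compound 3 (0.28 log units; within the scatter). Compound 4 `C=C(C)CC[C@]1(C)C2=CCC[C@](C)(C[C@H](O)C3=CC(=O)OC3O)[C@H]2CC[C@H]1C` carries the same change on the core of compound 2, namely (1-methylethenyl in place of 2-methylprop-2-en-1-yl on a saturated chain carbon, two bonds along the chain from a saturated ring carbon), and in this assay compound 4 has not yet been measured. Within the data shown here, compound 4 is expected to show a step of a 1.8-fold higher number from compound 2 to compound 4 (0.27 log units; within the scatter), resting on the earlier step because a 1.9-fold higher number from compound 1 to compound 3 (0.28 log units; within the scatter) is the only measured instance of this change in the set. The estimate for compound 4 in this assay is 7000 nM, with a range from 3500 nM to 14000 nM.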

Compound 4, half-maximal inhibitory concentration: 4800 nM
The estimate for compound 4 lay 1.5-fold (0.16 log units) above the measured number, within the range that was stated.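

In this assay, 1-methylethenyl in place of 2-methylprop-2-en-1-yl gives a 1.3-fold higher number from compound 2 to compound 4 (0.10 log units; within the scatter). Set beside the earlier step, the change reads alike on the two cores: the same change on two cores in this assay, a 1.9-fold higher number (0.28 log units; within the scatter) from compound 1 to compound 3 and a 1.3-fold higher number (0.10 log units; within the scatter) from compound 2 to compound 4, 1.5-fold (0.18 log units) apart, within the scatter of two such steps. This shows that the change carries between these two cores with no step beyond the scatter, but two pairs, both within the scatter, show no effect of chain length and give no rule for any other core.

Still open, as far as these compounds go, is whether a longer chain than 4-methylpent-4-en-1-yl would move the number beyond the scatter. The same question stands for a chain ending in an amine or a carboxylic acid in place of the double bond.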